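The compounds below may be only part of what the source reports. "The series", "measured", "known", "first", "only" and "open" are said of these compounds alone.

Measured so far in a functional assay on QGY7701 cells (Homo sapiens) for cytotoxicity, read by MTT assay, with a stated time of 24 h; on this read-out higher numbers stand for weaker inhibition and lower numbers for stronger inhibition: compound 1 `C=CC1=C(C(=O)NCc2ccc(Cl)cc2)C(c2ccc(OC)c(OC)c2)OC1` gives > 100000 nM, a limit of the assay. Compound 2 `C=CC1=C(C(=O)NCCC)C(c2ccc(OC)c(OC)c2)OC1` gives > 100000 nM, likewise a limit. Compound 3 `C=CC1=C(C(=O)Nc2cccc(C)c2)C(c2ccc(F)cc2)OC1` gives 56400 nM.

Compound 2 therefore stands only at the limit, where two of the three values sit (the limit of > 100000 nM in this assay, at which 2 of the 3 values shown sit). Compound 4 `C=CC1=C(C(=O)NCc2ccc(C)cc2)C(c2ccc(OC)c(OC)c2)OC1` differs from compound 2 by 4-methylphenyl in place of ethyl on a saturated chain carbon bound to an amide-type nitrogen. Going by the values given here, the one measured step at the same place, a step that the two limits leave unreadable from compound 1 to compound 2, is unreadable, both its ends being limits, so the data give neither a size nor a direction. Compound 1, which carries 4-chlorophenyl at that place, shows only its limit. The expected step is thus a step that the limit leaves unreadable from compound 2 to compound 4, nothing beyond the scatter. The estimate for compound 4 is 200000 nM, with a range from 60000 nM to 700000 nM.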

Compound 4, half-maximal inhibitory concentration: 69100 nM
Compound 4: the middle estimate sits 2.9-fold (0.46 log units) above what was measured; the measured number falls inside the stated range.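

In this assay, going by these compounds alone, compound 4 is the first compound with the core of compound 1 to give a number rather than a limit. Placing 4-methylphenyl in place of ethyl gives an at least 1.4-fold lower number from compound 2 to compound 4 (0.16 log units; that floor lies within the scatter), and methyl in place of chloro on an aromatic carbon gives an at least 1.4-fold lower number from compound 1 to compound 4 (0.16 log units; that floor lies within the scatter). Both steps are only floors, so neither change is shown to exceed the scatter: the limit of > 100000 nM in this assay, at which 2 of the 4 values shown sit.

Going by these compounds, the real size of both steps stays open. So does how a carboxylic acid in place of that methyl, or a chain longer than propyl, would read in this assay.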